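Replacing the 4-Fluoro-2-methoxyphenyl Group: Expected Clearance

The compounds below may be only part of what the source reports. "The series", "measured", "known", "first", "only" and "open" are said of these compounds alone.

Two measured compounds share a core. Compound 1 `COc1cc(F)ccc1-c1ccnc2[nH]c(C3CCN(CC(=O)N(C)C)CC3)cc12` carries a 4-fluoro-2-methoxyphenyl group, and in an ADME assay on microsomes from liver (Homo sapiens) for metabolic stability (on this read-out higher numbers stand for fast clearance and lower numbers for slow clearance), compound 1 gives 14 uL/min. Compound 2 `COc1cc(F)ccc1-c1ccnc2[nH]c(C3CCOCC3)cc12` in this assay gives 10 uL/min. Of the two numbers, that of compound 1 is the higher, but the gap to compound 2 is within the scatter, so the two cannot be told apart on this read-out.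

Compound 3 `CN(C)C(=O)CN1CCC(c2cc3c(-c4ccc(=O)n(C)c4)ccnc3[nH]2)CC1` has not been measured in this assay. It differs from compound 1 in one place: a group of 8 heavy atoms (6 carbon, 1 nitrogen, 1 oxygen; one six-membered aromatic ring with 1 hetero atom) in place of a group of 9 heavy atoms (7 carbon, 1 oxygen, 1 fluorine; one six-membered aromatic ring of carbon only), on an aromatic carbon. Within the data shown here, no pair of measured compounds shows a step of this kind, so nothing in the data sets its size. The step of a 1.4-fold lower number from compound 1 to compound 3 (0.15 log units; within the scatter) is expected to stay within the scatter, in either direction. Compound 3 is therefore expected to give 10 uL/min in this assay, with a range from 5 uL/min to 22 uL/min.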

Compound 3, intrinsic clearance in a liver preparation (reported as CLH), per the amount of preparation that the assay uses: < 3 uL/min
Compound 3 gave a limit, no number (the forecaster's own chance of this, stated with the estimate: 10%); at least 3.3-fold (0.52 log units) between middle value and limit.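

On the aromatic carbon opposite the ring nitrogen, replacing 4-fluoro-2-methoxyphenyl with the six-membered aromatic ring with 1 hetero atom moves the read-out in this assay, giving an at least 4.6-fold lower number from compound 1 to compound 3 (0.66 log units; beyond the scatter). Among these compounds, this is the first step at this position, and it shows that the position can shift clearance beyond the scatter, something the comparison of compound 1 with compound 2 could not show. Compound 3 gives a limit of the assay and not a number, so the step marks only the smallest size the change can have: the limit of < 3 uL/min in this assay, at which 1 of the 3 values shown sits.

The compounds shown do not separate the loss of the fluorine or the methoxy group from the entry of the ring nitrogen and the carbonyl. Also open, on these data alone, are how a plain phenyl group or an amine at this position would read, and whether the same change on compound 2 gives a similar step.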